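The source may hold more compounds than are shown below. What is called first, only, known or untested is meant among the compounds shown, and "the series" means these compounds.

Measured in a functional assay on MCF7 cells (Homo sapiens) for cytotoxicity; a higher number here means a weaker inhibitor, a lower number a stronger inhibitor:
- Compound 1 `C=C/C=C\[C@H](C)[C@H](OC(N)=O)[C@@H](C)[C@H](O)[C@@H](C)C/C(C)=C\[C@H](C)[C@@H](O)[C@@H](C)/C=C\CCc1cc(F)cc(F)c1`: 2000 nM
- Compound 2 `C=C/C=C\[C@H](C)[C@H](OC(N)=O)[C@@H](C)[C@H](O)[C@@H](C)C/C(C)=C\[C@H](C)[C@@H](O)[C@@H](C)/C=C\CCc1sccc1C`: 620 nM

Of these two, compound 2 has the lower number, 620 nM. Compound 3 `C=C/C=C\[C@H](C)[C@H](OC(N)=O)[C@@H](C)[C@H](O)[C@@H](C)C/C(C)=C\[C@H](C)[C@@H](O)[C@@H](C)/C=C\CCc1ccccc1` has phenyl in place of 3-methylthiophen-2-yl on a saturated chain carbon, two bonds along the chain from a double-bonded chain carbon. One measured change bears on this, at the same place, the modest 3.2-fold lower number from compound 1 to compound 2 (0.51 log units; beyond the scatter). Phenyl resembles the 3,5-difluorophenyl of compound 1, at 2000 nM, in being a six-membered aromatic ring of carbon only. A smaller step in the upward direction is therefore expected, estimated as a 1.5-fold higher number from compound 2 to compound 3 (0.16 log units; within the scatter). For compound 3 the expected value is 900 nM, with an estimated range of 350 nM to 2300 nM.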

Compound 3, half-maximal inhibitory concentration: 560 nM
The estimate for compound 3 lay 1.6-fold (0.21 log units) above the measured number; low and high end bracket the measured number.
By their numbers in this assay, from the lowest: compounds 3 and 2 (each within the scatter of the next); then compound 1.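

In this assay, the step with phenyl in place of 3-methylthiophen-2-yl is a 1.1-fold lower number from compound 2 to compound 3 (0.04 log units; within the scatter), so these two rings cannot be told apart here. A six-membered carbon ring alone therefore does not set compound 1 apart: removing its two fluorines gives a 3.6-fold lower number from compound 1 to compound 3 (0.55 log units; beyond the scatter), and the higher number goes with the 3,5-difluorophenyl group. Nothing available explains this difference. Still open, on these data alone, is whether a phenyl ring with a single fluorine, a methyl or an amine would track compound 1 or compound 3, and how a pyridine ring or a longer chain would fare.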